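Indole series: aromatic substituent effect on serotonin receptor 7 binding

The compounds below may be only part of what the source reports. "The series", "measured", "known", "first", "only" and "open" are said of these compounds alone.

Measured so far:
compound 1 `CN1CCCN(CCn2ccc3ccc(Br)cc32)CC1`: 93%
compound 2 `CCc1ccc2ccn(CCN3CCCN(C)CC3)c2c1`: 66%

Among the compounds with values here, in an assay on HEK293 cells for binding affinity to 5-hydroxytryptamine receptor 7 (Homo sapiens), read by radioligand binding, tested at 1 uM (on this read-out higher numbers stand for more inhibition at the one concentration tested (going by the name of the read-out) and lower numbers for less inhibition), compound 2 gives the lower of the two numbers; compound 1 stands higher, and the step of a number 27 percentage points lower from compound 1 to compound 2 (beyond the scatter) is the only measured change. It replaces bromo with ethyl on an aromatic carbon and lowers the read-out beyond the scatter.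

Compound 3 `CC(C)c1ccc2ccn(CCN3CCCN(C)CC3)c2c1` has not yet been measured in this assay. It differs from compound 2 by methyl in place of hydrogen on a saturated chain carbon bound to an aromatic carbon and a saturated chain carbon. No measured step covers the ethyl-to-isopropyl change itself; the single step from bromo to ethyl shows that a change at this aromatic position can move the read-out by a modest amount, but in which direction a further methyl would act is not shown. The expected step of a number 6 percentage points lower from compound 2 to compound 3 (within the scatter) is therefore small and likely within the scatter. The estimate for compound 3 is 60%, with a range from 40% to 80%.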

Compound 3, a percentage reported as inhibition, at one concentration (the size of the read-out at that concentration, not a potency): 72%
For compound 3 the middle estimate is 12 percentage points below the measured one; low and high end bracket the measured number.
By their numbers in this assay, from the lowest: compounds 2 and 3 (each within the scatter of the next); then compound 1.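

In this assay the ethyl to isopropyl change gives a step that stays inside the scatter (a number 6 percentage points higher from compound 2 to compound 3 (within the scatter)), so the added methyl on a saturated chain carbon bound to an aromatic carbon and a saturated chain carbon does not separate these two compounds. The change from bromo to isopropyl gives a step beyond the scatter (a number 21 percentage points lower from compound 1 to compound 3 (beyond the scatter)), so compound 1 now stands apart from both alkyl-bearing compounds, not from ethyl alone. No measured evidence bears on the reason for these numbers.

The compounds shown leave open whether another halogen, such as chloro or fluoro, on the same aromatic carbon would stay level with bromo. They also leave open whether a methoxy group or a longer chain such as n-butyl would fall with ethyl and isopropyl.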